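Half-life notes: from compound 2 to compound 4

The compounds below may be only part of what the source reports. "The series", "measured", "known", "first", "only" and "open" are said of these compounds alone.

Measured so far in an ADME assay on the whole organism (Rattus norvegicus, strain Wistar Han) for metabolic stability, read by LC-MS, with a stated time of 7 h; on this read-out higher numbers stand for a longer-lived compound and lower numbers for a shorter-lived compound
- compound 1 `CNC(=O)c1cc(C(=O)N[C@H]2CC[C@H](O)CC2)c([C@@H](C)c2cccc(Cl)c2)o1` gives 0.9 h
- compound 2 `CNC(=O)c1cc(C(=O)N[C@H]2[C@@H]3COC[C@@H]32)c([C@@H](C)c2ccccc2)o1` gives 0.7 h
- compound 3 `CNC(=O)c1cc(C(=O)N[C@H]2CC[C@H](OC)CC2)n([C@@H](C)c2ccccc2)n1` gives 1 h

Compound 2 stands at 0.7 h and lies within the usual scatter of both compound 1 and compound 3, so these three values show no order. Compound 4 `CNC(=O)c1cc(C(=O)N[C@H]2CC[C@H](O)CC2)c([C@@H](C)c2ccccc2)o1` has not yet been measured. Its difference from compound 2 is a group of 7 heavy atoms (6 carbon, 1 oxygen; one six-membered non-aromatic ring of carbon only) in place of a group of 6 heavy atoms (5 carbon, 1 oxygen; one three-membered non-aromatic ring of carbon only, one five-membered non-aromatic ring with 1 hetero atom), on an amide-type nitrogen and the group entering is 4-hydroxycyclohexyl, on an amide-type nitrogen. Going by the values given here, no measured pair isolates this change, so the expectation has only indirect support. Compound 1 also carries 4-hydroxycyclohexyl and gives 0.9 h within the scatter of compound 2, although it differs elsewhere as well. The expected change is a 1.1-fold higher number from compound 2 to compound 4 (0.06 log units; within the scatter) and no step beyond the scatter is anticipated in either direction. Compound 4 is estimated at 0.8 h with an expected range of 0.4 h to 1.6 h in this assay when measured.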

Compound 4, half-life: 1.3 h
The estimate for compound 4 lay 1.6-fold (0.21 log units) below the measured number; the range from low to high includes it.
By their numbers in this assay, from the lowest: compounds 2, 1, 3 and 4 (each within the scatter of the next).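

In this assay, going by these compounds alone, 4-hydroxycyclohexyl in place of the group with the three-membered and five-membered rings, on the amide-type nitrogen, gives a 1.9-fold higher number from compound 2 to compound 4 (0.27 log units; within the scatter) and so puts this change on a direct one-place comparison that the earlier compounds did not offer. Hydrogen in place of chloro on an aromatic carbon gives a 1.4-fold higher number from compound 1 to compound 4 (0.16 log units; within the scatter) in the same read-out, so neither single change separates its pair beyond the scatter. No supporting data are available to explain either step.

As far as these compounds go, whether a carboxylic acid or a primary amine in place of the hydroxyl of 4-hydroxycyclohexyl would give a step beyond the scatter remains open. Also open, from the compounds shown here alone, is whether either step carries over to the core of compound 3.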